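This account rests on a few compounds, and the source may have more. Where it says the series, first, only, none or still open, it means among the compounds named here.

In a functional assay on OVCAR-3 cells (Homo sapiens) for antiproliferative activity, read by MTT assay, with a stated time of 24 h (on this read-out lower numbers stand for stronger inhibition and higher numbers for weaker inhibition), compound 1 `Cc1cccc(NNC(=O)c2ccccc2NS(=O)(=O)c2cnc(O)nc2O)c1` gives > 20000 nM as a limit and not a number. Compound 2 `Cc1ccccc1C(=O)NNC(=O)c1ccccc1NS(=O)(=O)c1cnc(O)nc1O` gives > 20000 nM as a limit too. Compound 2 thus stands at the limit of > 20000 nM in this assay, at which 2 of the 2 values shown sit, and has no number of its own. Compound 3 `Cc1ccc(C(=O)NNC(=O)c2ccccc2NS(=O)(=O)c2cnc(O)nc2O)cc1` differs from compound 2 in one place: 4-methylphenyl in place of 2-methylphenyl on a carbonyl carbon. Among the measured compounds shown here, the one measured step that bears on this is a step that the two limits leave unreadable from compound 1 to compound 2 and it offers no size to carry over. No shift beyond the scatter is therefore expected in this assay in either direction. The expectation rests on compound 2 at > 20000 nM and that is only a limit. The expected change is a step that the limit leaves unreadable from compound 2 to compound 3 as estimated from that limit. For compound 3 the estimated value is 25000 nM with an expected range from 10000 nM to 60000 nM and a report as a limit again is the likeliest outcome.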

Compound 3, half-maximal inhibitory concentration: 12900 nM
Estimate against measurement, compound 3: 1.9-fold (0.29 log units) above; the measured number falls inside the stated range.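

In this assay, among the compounds shown here, compound 3 is the first of the series with a number of its own (12900 nM), so 4-methylphenyl in place of 2-methylphenyl on a carbonyl carbon brings the value within the measurable range. The change reads as an at least 1.5-fold lower number from compound 2 to compound 3 (0.19 log units; that floor lies within the scatter) and the comparison with the arylamine compound reads as an at least 1.5-fold lower number from compound 1 to compound 3 (0.19 log units; that floor lies within the scatter); both are floors and not measured gaps. The step between the two earlier compounds cannot be read, and each of them carries only a limit: the limit of > 20000 nM in this assay, at which 2 of the 3 values shown sit.

The compounds shown leave open whether another group on this phenyl ring, such as an amine, a carboxylic acid or a longer chain in place of methyl, would keep a measurable number in this assay. They also leave open the true size of the gap between compound 2 and compound 3.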